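The source may hold more compounds than are shown below. What is called first, only, known or untested is meant among the compounds shown, and "the series" means these compounds.

In a functional assay on HeLa cells (Homo sapiens) for antiproliferative activity, read by MTT assay, with a stated time of 48 h (a lower number here means a stronger inhibitor, a higher number a weaker inhibitor), the compounds stand as follows:

Compound 1 `COc1ccc(N(C)c2ccnc(Cl)n2)cc1F` gives 241 nM in this read-out
Compound 2 `COc1ccc(N(C)c2ccnc(Cl)n2)cc1OCCCCCBr` gives 7090 nM in this read-out
Compound 3 `COc1ccc(N(C)c2ccnc(Cl)n2)cc1OCCC[Se]C#N` has not yet been measured

Compound 2, at 7090 nM in this assay, holds the higher of the two numbers, while compound 1 gives 241 nM in the same test. Among the measured compounds shown here, the one measured step, a 29-fold higher number from compound 1 to compound 2 (1.47 log units; beyond the scatter), is large and beyond the scatter. It puts (5-bromopentyl)oxy in place of fluoro on an aromatic carbon.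

Compound 3 differs from compound 2 only at the end of that chain. The change reads a group of 3 heavy atoms (1 carbon, 1 nitrogen, 1 selenium; no ring) in place of a group of 3 heavy atoms (2 carbon, 1 bromine; no ring), on a saturated chain carbon, three bonds along the chain from an oxygen on an aromatic ring and nothing else differs. For the measured compounds named here, no measured step touches this place, so the single step bears on it only indirectly, showing that numbers in this small set can move widely. A moderate shift toward a lower number is expected, but the data cannot fix its size, and no change beyond the scatter remains possible. The expected move is a 5.9-fold lower number from compound 2 to compound 3 (0.77 log units; beyond the scatter) and it carries wide uncertainty. The estimated value for compound 3 is 1200 nM with an expected range from 150 nM to 7000 nM in repeated measurements.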

Compound 3, half-maximal inhibitory concentration: 4710 nM
For compound 3 the middle estimate is 3.9-fold (0.59 log units) below the measured one; the measured number falls inside the stated range.
By their numbers in this assay, from the lowest: compound 1; then compounds 3 and 2 (each within the scatter of the next).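

In this assay, placing the group of carbon, nitrogen and selenium in place of 2-bromoethyl, on a saturated chain carbon, three bonds along the chain from an oxygen on an aromatic ring, gives a 1.5-fold lower number from compound 2 to compound 3 (0.18 log units; within the scatter), so this change at the chain end does not separate the two compounds in this read-out. The earlier pair showed only that one bromine-ended chain in place of fluoro carried a large penalty, whereas the selenium-bearing chain now gives a 20-fold higher number from compound 1 to compound 3 (1.29 log units; beyond the scatter). Both chain-bearing compounds thus stand well above compound 1, and neither chain end, as far as these compounds go, brings the number back toward that of compound 1.

Nothing available explains why the two chain ends read alike or why both stand so far from compound 1.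

The compounds shown leave open whether the large steps follow from the chain itself or from its end, which a plain unsubstituted alkoxy chain in place of fluoro would help to separate. They also leave open how an amine or a carboxylic acid at the end of the chain would read, and whether a longer chain ending in the same selenium group would read differently.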